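The source may report more compounds than this note shows. Statements on the series, on what has been measured and on what is new or still open speak of the compounds shown alone.

Measured in an ADME assay on BHK cells (Mesocricetus auratus) for cytotoxicity, read by MTT assay, with a stated time of 96 h; on this read-out higher numbers stand for lower toxicity in this test and lower numbers for higher toxicity in this test:

- compound 1 `FC(F)(F)c1cccc(NC(=S)Nc2ccc(I)cc2)c1`: 9400 nM
- compound 2 `COc1cccc(NC(=S)Nc2cccc(C(F)(F)F)c2)c1`: 12000 nM
- compound 3 `Cc1ccc(NC(=S)Nc2cccc(C(F)(F)F)c2)cc1Cl`: 10000 nM

These three values lie within the usual scatter of one another, so they cannot be put in any order. Compound 1, at 9400 nM, stands level with the other two, and none of them can be called more or less toxic in this test.

The next compound is compound 4 `CC(=O)NC(=S)Nc1cccc(C(F)(F)F)c1`, still to be measured. Going from compound 1 to compound 4 puts acetyl in place of 4-iodophenyl on an amide-type nitrogen. Among the compounds with values here, compound 2 and compound 3 each still carry a ring at that place, so no measured compound shows what happens without one, and no measured step between compounds can serve as a guide.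

In this assay, within the data shown here, compound 2 at 12000 nM and compound 3 at 10000 nM show only that the different rings tried so far leave the number within the scatter. The change in compound 4 is much larger, so a modest rise is expected, with a return to the same level still possible. The expected change is a 2.7-fold higher number from compound 1 to compound 4 (0.42 log units; beyond the scatter), and this is only an estimate. For compound 4 the estimated value is 25000 nM, with an expected range from 9000 nM to 70000 nM.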

Compound 4, half-maximal cytotoxic concentration: > 100000 nM
Compound 4 ended at the assay's limit; the forecaster's own chance of this, stated with the estimate: 30%; middle value at least 4.0-fold (0.60 log units) away from the limit.
By their numbers in this assay, from the lowest: compounds 1, 3 and 2 (each within the scatter of the next). At a limit, above all of these: compound 4.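

Swapping 4-iodophenyl for acetyl on the amide-type nitrogen gives an at least 10-fold higher number from compound 1 to compound 4 (1.02 log units; beyond the scatter) in this assay, a large step beyond the scatter, and on this read-out a higher number stands for lower toxicity in this test. Until now every compound carried a ring at this place and all sat within the scatter of one another, which made the place look indifferent to the change, whereas this single ringless compound shows that the number can move far when the ring goes and acetyl takes its place. For compound 4 the reading of > 100000 nM is a limit of the assay and not a number, so the step gives only a lower bound on the change, not its full size: the limit of > 100000 nM in this assay, at which 1 of the 4 values shown sits.

The compounds shown cannot separate the loss of the ring from the arrival of the acetyl carbonyl, since both happen in the same step. Going by these compounds, a benzoyl group, which keeps a ring together with a carbonyl, or a plain butyl chain, which has neither, would pull these two apart, and whether other groups at this place behave like acetyl remains open.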